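Adding a second fluorine to a diphenylmethyl piperidine

A few compounds are considered here, and "the series" means these few. Any claim that something is new, unique, unknown or untested is made for them only; others in the source may bear on it.

Compound 1 `COc1cc(C(C)=O)ccc1OCCCN1CCC(C(c2ccccc2)c2ccccc2)CC1` is measured in a functional assay (aorta) with Oryctolagus cuniculus as the target (a lower number here means tighter binding, a higher number weaker binding), where compound 1 gives 6.31 nM. Compound 2 `COc1cc(C(C)=O)ccc1OCCCN1CCC(C(c2ccccc2)c2ccc(F)cc2)CC1` differs from it by fluoro in place of hydrogen on an aromatic carbon, and compound 2 gives 6.31 nM, so no change at the digits printed from compound 1 to compound 2 (within the scatter). Compound 3 `COc1cc(C(C)=O)ccc1OCCCN1CCC(C(c2ccc(F)cc2)c2ccc(F)c(F)c2)CC1` gives 1.26 nM; the step is a 5.0-fold lower number from compound 2 to compound 3 (0.70 log units; beyond the scatter). The difference between the cores of compound 1 and compound 3 is not broken down here. Compound 4 `COc1cc(C(C)=O)ccc1OCCCN1CCC(C(c2ccc(F)c(F)c2)c2ccc(F)c(F)c2)CC1` is not yet measured; it differs from compound 3 by fluoro in place of hydrogen on an aromatic carbon, the same kind of change as from compound 1 to compound 2, though here the place is ortho to a fluoro group and meta to a large group rather than para to a large group. Because no change at the digits printed from compound 1 to compound 2 (within the scatter), only a small step is expected, a 1.4-fold lower number from compound 3 to compound 4 (0.15 log units; within the scatter), and compound 4 is estimated at 0.9 nM.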

Compound 4, dissociation constant: 2.51 nM
Estimate against measurement, compound 4: 2.8-fold (0.45 log units) below, and the stated range ends below it.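

In this assay, adding the fluoro group that turns the 4-fluorophenyl of compound 3 into the 3,4-difluorophenyl of compound 4 gives a 2.0-fold higher number from compound 3 to compound 4 (0.30 log units; within the scatter). Replacing hydrogen with fluoro on an aromatic carbon therefore looks alike on the two cores, with neither step standing out from the scatter: the same change on two cores in this assay, no change at the digits printed (within the scatter) from compound 1 to compound 2 and a 2.0-fold higher number (0.30 log units; within the scatter) from compound 3 to compound 4, 2.0-fold (0.30 log units) apart, within the scatter of two such steps. Within the data shown here, this rests on only two cores and two ring places, so it does not show that the change would be as small on every core or at every ring position.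

Going by these compounds, whether another group in this place, such as trifluoromethyl or a nitrile, would give a step beyond the scatter remains open. So does whether the fluoro step would stay this small with a longer chain joining the two parts of the molecule.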